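A Halogen Swap at the Edge of Detection

This account rests on a few compounds, and the source may have more. Where it says the series, first, only, none or still open, it means among the compounds named here.

Compound 1 `N#CC1=C(N)Oc2cc3oc(-c4ccccc4)cc(=O)c3c(O)c2C12C(=O)Nc1ccccc12` gives > 50000 nM in a functional assay on NCI-H1299 cells (Homo sapiens) for antiproliferative activity, read by MTT assay, with a stated time of 48 h (on this read-out lower numbers stand for stronger inhibition and higher numbers for weaker inhibition), a value that is a limit of the assay and not a number.
Compound 2 `CCN1C(=O)C2(C(C#N)=C(N)Oc3cc4oc(-c5ccc(OC)cc5OC)cc(=O)c4c(O)c32)c2cc(Cl)ccc21` gives > 50000 nM in this assay, again a limit of the assay rather than a number.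

Compound 2 therefore stands at the ceiling of what this assay reports, and compound 1 sits at the same ceiling, so the two values show nothing beyond the fact that neither compound produced a measurable inhibition. This is summed up by the limit of > 50000 nM in this assay, at which 2 of the 2 values shown sit.

Compound 3 `CCN1C(=O)C2(C(C#N)=C(N)Oc3cc4oc(-c5ccc(OC)cc5OC)cc(=O)c4c(O)c32)c2cc(Br)ccc21` differs from compound 2 in one place: bromo in place of chloro on an aromatic carbon of a six-membered aromatic ring of carbon only, part of a fused or bridged system of five rings, meta to a fused ring and para to a fused ring. Within the data shown here, no step between measured compounds is available to calibrate this exchange.

Since compound 2 gave only a limit, compound 3 is expected to remain at or near that limit, with a step that the limit leaves unreadable from compound 2 to compound 3, nothing beyond the scatter. The estimate for compound 3 is 60000 nM, within 20000 nM to 200000 nM.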

Compound 3, half-maximal inhibitory concentration: > 50000 nM
Compound 3: only a limit was reported; the forecaster's own chance of this, stated with the estimate: 80%; the middle value is on the limit's open side.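

Compound 3 gives > 50000 nM in this assay, a limit of the assay and not a number. Compound 2 also carries only a limit, so no step can be read for bromo in place of chloro. The compounds shown leave open whether any change to the shared core yields a measurable value: the limit of > 50000 nM in this assay, at which 3 of the 3 values shown sit.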